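The source may report more compounds than this note shows. Statements on the series, on what has been measured and on what is new or still open speak of the compounds shown alone.

Compound 1 `NCC1COCC(c2ccccc2)(c2ccccc2)O1`: 31200 nM
Compound 2 `NC[C@@H]1COCC(c2ccccc2)(c2ccccc2)O1`: 74000 nM

In a functional assay on SK-BR-3 cells (Homo sapiens) for cytotoxicity, read by sulforhodamine B assay, with a stated time of 48 h (on this read-out higher numbers stand for weaker inhibition of growth and lower numbers for stronger inhibition of growth), compound 2 stands highest of the two measured compounds, so it shows the weaker inhibition of growth. Compound 3 `NC[C@H]1COCC(c2ccccc2)(c2ccccc2)O1` departs from compound 2 as follows: the two compounds have the same atoms and bonds and differ only in configuration as drawn: 1 of 1 stereo elements differ; a stereocentre at a saturated ring carbon is drawn R in compound 2 and S in compound 3. For the measured compounds named here, one measured step bears on this, the modest 2.4-fold higher number from compound 1 to compound 2 (0.38 log units; beyond the scatter), and what goes with it is the fact that one of compounds 1 and 2 is drawn with a defined configuration and the other without, at the place where they differ. Fixing this stereocentre as R raised the number, so the S form is expected to move the opposite way, by a similar or somewhat larger amount. The expected change is a 3.4-fold lower number from compound 2 to compound 3 (0.53 log units; beyond the scatter). The estimated value for compound 3 is 22000 nM, within an expected range of 9000 nM to 60000 nM.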

Compound 3, concentration for 50% growth inhibition: 23000 nM
The estimate for compound 3 lay 1.0-fold (0.02 log units) below the measured number, and the stated range covers the measured number.
By their numbers in this assay, from the lowest: compounds 3 and 1 (each within the scatter of the next); then compound 2.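

In this assay, fixing the configuration at this ring carbon clearly matters, with a 3.2-fold lower number from compound 2 to compound 3 (0.51 log units; beyond the scatter). The S form inhibits growth more strongly than the R form, and the comparison is a clean one: the fact that compounds 2 and 3 differ only in the configuration as drawn. The S form cannot be told apart from the form drawn without a configuration, with a 1.4-fold lower number from compound 1 to compound 3 (0.13 log units; within the scatter): the fact that one of compounds 1 and 3 is drawn with a defined configuration and the other without, at the place where they differ.

From the compounds shown here alone, it remains open whether the S form keeps its advantage when a carboxylic acid replaces the amine or when a chlorine sits on the phenyl rings.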